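Changing the Aryl Group on the Amide Nitrogen

The source may hold more compounds than are shown below. What is called first, only, known or untested is meant among the compounds shown, and "the series" means these compounds.

compound 1 `CCOC1=C(/C(C)=N/OCC(=O)Nc2cccc(F)c2)N(C)S(=O)(=O)c2ccccc21` — > 20000 nM
compound 2 `CCOC1=C(/C(C)=N/OCC(=O)Nc2ccc(F)c(Cl)c2)N(C)S(=O)(=O)c2ccccc21` — > 20000 nM

In a functional assay on THP-1 cells (Homo sapiens) for inhibition, read by ELISA, with stated times of 2 h and 48 h (a higher number here means a weaker inhibitor, a lower number a stronger inhibitor), compound 1 gives only a limit of the assay, > 20000 nM. Compound 2 likewise gives only a limit in this assay, > 20000 nM. The step that the two limits leave unreadable from compound 1 to compound 2 therefore has no readable size. Going by the values given here, compound 2 thus stands at the limit of > 20000 nM in this assay, at which 2 of the 2 values shown sit, and nothing among the measured values places it anywhere more precisely.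

Compound 3 `CCOC1=C(/C(C)=N/OCC(=O)Nc2c(F)cccc2F)N(C)S(=O)(=O)c2ccccc21` carries the change (2,6-difluorophenyl in place of 3-chloro-4-fluorophenyl on an amide-type nitrogen). Among the compounds with values here, the only measured step, from compound 1 to compound 2, is unreadable, so no measured change of this kind gives a size or direction for the new step. The estimate for compound 3 in this assay is therefore a value most likely to be reported again as a limit, 20000 nM, with a range from 5000 nM to 60000 nM. The step this estimate means, a number no higher from compound 2 to compound 3 (the limit leaves the size open), is expected to be no change beyond the scatter.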

Compound 3, half-maximal inhibitory concentration: > 20000 nM
Compound 3 ended at the assay's limit; the forecaster's own chance of this, stated with the estimate: 80%; the middle value sits exactly at the limit.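

In this assay compound 3 gives only a limit of the assay, > 20000 nM. The steps linking compound 3 with compound 1 and compound 2 therefore cannot be read. The compounds shown leave open whether these aryl groups on the amide-type nitrogen differ at all: the limit of > 20000 nM in this assay, at which 3 of the 3 values shown sit.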